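Swapping an Ester Chain End for a Piperidine

The source may hold more compounds than are shown below. What is called first, only, known or untested is meant among the compounds shown, and "the series" means these compounds.

In a functional assay on the whole organism (B cells) with Mus musculus as the target (a higher number here means a larger maximal response, a lower number a smaller maximal response), compound 2 `CCOC(=O)Cn1c(=O)n(C2OC(CO)[C@@H](O)[C@H]2O)c2nc(N)nc(O)c21` gives 86%, the second highest of the three measured numbers. Compound 1 `COc1ccc(Cn2c(=O)n(C3OC(CO)[C@@H](O)[C@H]3O)c3nc(N)nc(O)c32)cc1` gives 44%, and compound 3 `Cn1c(=O)n([C@@H]2O[C@H](CO)[C@H]3OC(C)(C)O[C@H]32)c2nc(N)nc(O)c21` gives 193%, so compound 2 lies between them and nearer to compound 1. The unmeasured compound 4 `Nc1nc(O)c2c(n1)n(C1OC(CO)[C@@H](O)[C@H]1O)c(=O)n2CCN1CCCCC1` differs from compound 2 in a single place: (piperidin-1-yl)methyl in place of ethoxycarbonyl on a saturated chain carbon bound to an aromatic nitrogen. Within the data shown here, only one measured step concerns the same place, a number 42 percentage points higher from compound 1 to compound 2 (beyond the scatter), and it was large, showing that exchanges on this chain carbon can move the read-out strongly. Among the measured compounds shown here, no measured pair shows this exact exchange, so its direction is uncertain. For compound 4 the value is expected to be about 100%, between 50% and 160%, which would be an estimated step of a number 14 percentage points higher from compound 2 to compound 4 (beyond the scatter).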

Compound 4, largest response reached (reported as maximal response), in percent of the reference or control that the assay uses: 0%
Compound 4: the middle estimate sits 100 percentage points above what was measured; the whole stated range lies above it.
By their numbers in this assay, from the lowest: compound 4; then compound 1; then compound 2; then compound 3.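

With (piperidin-1-yl)methyl on the saturated chain carbon bound to an aromatic nitrogen, this assay shows a number 86 percentage points lower from compound 2 to compound 4 (beyond the scatter) and a number 44 percentage points lower from compound 1 to compound 4 (beyond the scatter) as well. Changes at this position can therefore wipe out the read-out entirely rather than only shift it, whether ethoxycarbonyl or 4-methoxyphenyl is the group replaced. Nothing available explains this loss. From the compounds shown here alone, it remains open whether the drop follows the piperidine ring itself or the amine nitrogen at the chain end. A morpholine ring, an open dimethylamino end or a carboxylic acid on the same chain would help separate these possibilities.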